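Replacing 3-chlorophenyl with 2,3,4,5,6-pentafluorophenyl

The source may report more compounds than this note shows. Statements on the series, on what has been measured and on what is new or still open speak of the compounds shown alone.

In a functional assay on MCF7 cells (Homo sapiens) for inhibition, read by MTT assay, with a stated time of 48 h (a higher number here means a weaker inhibitor of growth, a lower number a stronger inhibitor of growth), compound 1 `CN1CC[C@H](c2c(O)cc(O)c3c(=O)cc(/C=C/c4ccccc4)oc23)[C@H](O)C1` gives 31000 nM and compound 2 `CN1CC[C@H](c2c(O)cc(O)c3c(=O)cc(/C=C/c4ccc(Cl)cc4)oc23)[C@H](O)C1` gives 49000 nM, with a 1.6-fold higher number from compound 1 to compound 2 (0.20 log units; within the scatter). Compound 3 `CN1CC[C@H](c2c(O)cc(O)c3c(=O)cc(/C=C/c4cccc(Cl)c4)oc23)[C@H](O)C1` gives 2000 nM, the lowest number of the three. Compound 4 `CN1CC[C@H](c2c(O)cc(O)c3c(=O)cc(/C=C/c4c(F)c(F)c(F)c(F)c4F)oc23)[C@H](O)C1` differs from compound 3 by 2,3,4,5,6-pentafluorophenyl in place of 3-chlorophenyl on a double-bonded chain carbon bound to a double-bonded chain carbon. Among the measured compounds shown here, no measured step tests this change directly. The two large steps, a 16-fold lower number from compound 1 to compound 3 (1.19 log units; beyond the scatter) and a 25-fold lower number from compound 2 to compound 3 (1.39 log units; beyond the scatter), both end at the 3-chlorophenyl group, which leaves in this change, so a large step towards a higher number is expected in this assay. The expected step is a 7.5-fold higher number from compound 3 to compound 4 (0.88 log units; beyond the scatter). For compound 4 the estimated value is 15000 nM, with an expected range from 3000 nM to 60000 nM.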

Compound 4, concentration for 50% growth inhibition: 8000 nM
Compound 4: the middle estimate sits 1.9-fold (0.27 log units) above what was measured; the measured number falls inside the stated range.
By their numbers in this assay, from the lowest: compound 3; then compound 4; then compounds 1 and 2 (each within the scatter of the next).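

In this assay, the 2,3,4,5,6-pentafluorophenyl group gives back part of the gain seen with 3-chlorophenyl, with a 4.0-fold higher number from compound 3 to compound 4 (0.60 log units; beyond the scatter), yet it keeps a clear lead over the other two groups, with a 6.1-fold lower number from compound 2 to compound 4 (0.79 log units; beyond the scatter) and a 3.9-fold lower number from compound 1 to compound 4 (0.59 log units; beyond the scatter). At this place, then, a lower number than that of the phenyl compound is not confined to 3-chlorophenyl, although compound 2, with 4-chlorophenyl, does not separate from compound 1.

No measurement shown here explains these steps. As far as these compounds go, whether a ring carrying a methoxy group, a nitrile or an amine would stand nearer compound 3 or compound 4 remains open.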